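The source may hold more compounds than are shown below. What is called first, only, known or untested is meant among the compounds shown, and "the series" means these compounds.

In an ADME assay on a cell-free system (serum) for metabolic stability (on this read-out lower numbers stand for a shorter-lived compound and higher numbers for a longer-lived compound), compound 1 `CC(C)(C)c1cc(OC(=O)c2ccc(Cl)cc2Cl)ccc1O` gives 0.167 h. Compound 2 `Cc1ccc(C(=O)Oc2ccc(O)c(C(C)(C)C)c2)cc1` returns only a limit, < 0.25 h. Compound 3 `CC(C)(C)c1cc(OC(=O)c2ccccc2)ccc1O` is still unmeasured. It carries hydrogen in place of methyl on an aromatic carbon, para to a large group, so that 4-methylphenyl becomes phenyl: hydrogen in place of methyl on an aromatic carbon. Compound 1, at 0.167 h, is short-lived as well, so no change beyond the usual scatter is expected in this assay. The expected step that the limit leaves unreadable from compound 2 to compound 3 therefore stays within that scatter, in neither direction. Compound 3 is estimated at 0.17 h, with an expected range of 0.08 h to 0.35 h.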

Compound 3, half-life: < 0.25 h
Compound 3: a limit, no number (the forecaster's own chance of this, stated with the estimate: 50%); the middle value lies beyond the limit too.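

In this assay compound 2 and compound 3 each give only a limit, so no step can be read between them: the limit of < 0.25 h in this assay, at which 2 of the 3 values shown sit. Going by these compounds, whether hydrogen in place of methyl on an aromatic carbon changes the half-life at all stays open.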